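Second chloro on the aryl ring of compound 2

This account rests on a few compounds, and the source may have more. Where it says the series, first, only, none or still open, it means among the compounds named here.

Compound 1 `N#C/C(=C\N1CCN(C(=O)c2ccco2)C1=S)C(N)=O` and compound 2 `O=CN1CCN(c2ccc(Cl)cc2)C1=S` have both been measured in a functional assay on TK-10 cells (Homo sapiens) for inhibition, read by sulforhodamine B assay, with a stated time of 48 h; on this read-out higher numbers stand for weaker inhibition of growth and lower numbers for stronger inhibition of growth. Compound 1 gives 12100 nM. Compound 2 gives 15000 nM; of the two numbers this is the higher, yet compound 1 is the nearest point and the gap between them falls within the usual scatter, so the pair shows two weak inhibitors of similar standing and nothing more. Compound 3 `O=CN1CCN(c2ccc(Cl)c(Cl)c2)C1=S` has not yet been measured in this assay. The change from compound 2 to compound 3 is chloro in place of hydrogen on an aromatic carbon. Within the data shown here, no measured pair of this kind exists, so the size of the step rests on expectation alone. A second chloro on the same ring is expected to move the number only modestly, with no clear direction beyond the scatter. The expected step is a 1.3-fold lower number from compound 2 to compound 3 (0.10 log units; within the scatter). Compound 3 is accordingly estimated at 12000 nM, with a range from 5000 nM to 30000 nM.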

Compound 3, concentration for 50% growth inhibition: 16500 nM
Estimate against measurement, compound 3: 1.4-fold (0.14 log units) below, within the range that was stated.
By their numbers in this assay, from the lowest: compounds 1, 2 and 3 (each within the scatter of the next).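

In this assay, among these compounds, chloro in place of hydrogen on an aromatic carbon, ortho to a chloro group, gives a 1.1-fold higher number from compound 2 to compound 3 (0.04 log units; within the scatter) and provides the first measured step of any kind. This carbon of the six-membered aromatic ring therefore takes a second chloro with no reading beyond the scatter, and compound 3 stands level with compound 2 as a weak inhibitor of growth. No measured property bears on this result, so the step carries no explanation.

As far as these compounds go, whether a different group on this carbon, such as an amine, a carboxylic acid or a longer chain, would move the number beyond the scatter remains open. Equally open, from the compounds shown here alone, is what a ring carrying only the new chloro would read.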